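A few compounds are considered here, and "the series" means these few. Any claim that something is new, unique, unknown or untested is made for them only; others in the source may bear on it.

In a functional assay on DLD-1 cells (Homo sapiens) for cytotoxicity, read by MTT assay (a higher number here means a weaker inhibitor, a lower number a stronger inhibitor), the measured compounds are:

compound 1 `CCOc1cc(/C=C/C(=O)C(=Cc2ccc(O)c(OC)c2)C(=O)/C=C/c2ccc(O)c(OCC)c2)ccc1O`: 9630 nM
compound 2 `CCOc1cc(/C=C/C(=O)C(=Cc2ccc(O)cc2)C(=O)/C=C/c2ccc(O)c(OCC)c2)ccc1O`: 20300 nM
compound 3 `CCOc1cc(/C=C/C(=O)C(=Cc2ccc(O)c(O)c2)C(=O)/C=C/c2ccc(O)c(OCC)c2)ccc1O`: 5100 nM

Compound 3 sits at the low end of these numbers, but it shares that place with one other compound: a 1.9-fold lower number from compound 1 to compound 3 (0.28 log units; within the scatter). Its clear gap is to the remaining compound: a 4.0-fold lower number from compound 2 to compound 3 (0.60 log units; beyond the scatter).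

The next compound is compound 4 `CCOc1cc(/C=C/C(=O)C(=Cc2ccc(OCC)c(OCC)c2)C(=O)/C=C/c2ccc(O)c(OCC)c2)ccc1O`, which carries 3,4-diethoxyphenyl in place of 3,4-dihydroxyphenyl on a double-bonded chain carbon bound to a double-bonded chain carbon.

For the measured compounds named here, two measured steps bear on this change. Swapping a methyl on an oxygen for hydrogen gave a 1.9-fold lower number from compound 1 to compound 3 (0.28 log units; within the scatter), so that change stayed inside the noise. Losing the methoxy altogether gave a 2.1-fold higher number from compound 1 to compound 2 (0.32 log units; beyond the scatter). Going by the values given here, no measured compound has ethoxy on this group or has both of its hydroxy groups capped, so the guide is only partial.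

A modest rise is expected, estimated as a 2.0-fold higher number from compound 3 to compound 4 (0.29 log units; within the scatter). For compound 4 the estimated value is 10000 nM, with an expected range of 3500 nM to 28000 nM.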

Compound 4, half-maximal inhibitory concentration: 3450 nM
Compound 4: middle estimate off by 2.9-fold (0.46 log units), on the high side; the whole stated range lies above it.
By their numbers in this assay, from the lowest: compounds 4, 3 and 1 (each within the scatter of the next, the first and the last beyond it); then compound 2.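

In this assay, 3,4-diethoxyphenyl and 3,4-dihydroxyphenyl cannot be told apart on a double-bonded chain carbon bound to a double-bonded chain carbon (a 1.5-fold lower number from compound 3 to compound 4 (0.17 log units; within the scatter)), so this position accepts a group with 12 heavy atoms and 0 hydrogen-bond donors as readily as one with 8 heavy atoms and 2 donors. The same group also stands clearly apart from the two others that have a single hydroxy on this ring, 4-hydroxyphenyl (a 5.9-fold lower number from compound 2 to compound 4 (0.77 log units; beyond the scatter)) and 4-hydroxy-3-methoxyphenyl (a 2.8-fold lower number from compound 1 to compound 4 (0.45 log units; beyond the scatter)), so among these compounds a free hydroxy on this ring is not needed for a low number. Nothing available explains why the capped and uncapped groups give such similar results. Still open, on these data alone, is whether one ethoxy paired with one hydroxy would serve as well as two ethoxy groups. Also open, as far as these compounds go, is how a longer chain such as butoxy, an amine or a carboxylic acid on this ring would fare.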